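The source may report more compounds than this note shows. Statements on the series, on what has been measured and on what is new or still open speak of the compounds shown alone.

In a physicochemical assay for solubility, with a stated time of 3 days, at pH 2 (on this read-out higher numbers stand for higher solubility and lower numbers for lower solubility), the compounds read as follows:

compound 1 `NC(=O)c1ccc2[nH]c(-c3ccc(OCC4CCCNC4)cc3)nc2c1`: "not determined" (no result reported)
compound 2 `COc1ccc(CN2CCCCC2CCOc2ccc(-c3nc4cc(C(N)=O)ccc4[nH]3)cc2)cc1`: > 400000 nM
compound 3 `CC(=O)N1CCCC(COc2ccc(-c3nc4cc(C(N)=O)ccc4[nH]3)cc2)C1`: "not determined" (no result reported)

Compound 3 has no place on the scale, since its entry reads "not determined" (no result reported) and no number stands for it. Compound 1 is in the same position, with "not determined" (no result reported) as its entry. Compound 2 gives > 400000 nM and this is a limit of the assay, not a number. The only figure in the series is therefore the limit of > 400000 nM in this assay, at which 1 of the 3 values shown sits, and it belongs to compound 2.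

Compound 4 `CC(=O)N1CCCCC1CCOc1ccc(-c2nc3cc(C(N)=O)ccc3[nH]2)cc1` has yet to be measured in this assay and is the compound followed here. Its structure departs from that of compound 3 in one place: (1-acetylpiperidin-2-yl)methyl stands in place of 1-acetylpiperidin-3-yl on a saturated chain carbon bound to an oxygen on an aromatic ring ((1-acetylpiperidin-2-yl)methyl in place of 1-acetylpiperidin-3-yl on a saturated chain carbon bound to an oxygen on an aromatic ring).

For the measured compounds named here, no pair of measured compounds gives a size for a change of this kind. The expectation in this assay is therefore no step beyond the usual scatter, in either direction. The sole anchor is the limit of compound 2 at > 400000 nM and it fixes no exact level. For compound 4 the solubility is estimated at 250000 nM with an expected range from 60000 nM to 400000 nM in this measurement.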

Compound 4, solubility: > 400000 nM
Compound 4: no number, only a limit; the forecaster's own chance of this, stated with the estimate: 45%; at least 1.6-fold (0.20 log units) between middle value and limit.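

In this assay compound 4 gives > 400000 nM and this is a limit of the assay, not a number. For the compounds shown here, compound 2 and compound 4 both stand at a limit, so no step between them can be read: the limit of > 400000 nM in this assay, at which 2 of the 4 values shown sit. The compounds shown leave open how far acetyl in place of 4-methoxybenzyl on an amine nitrogen in a ring shifts this read-out, if at all.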